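This account rests on a few compounds, and the source may have more. Where it says the series, first, only, none or still open, it means among the compounds named here.

Measured so far: compound 1 `Cc1ccc(NC(=O)N[C@@H](C)c2ccccc2)cc1` gives 99% in an ADME assay on the whole organism with Oryza sativa as the target, tested at 1 uM (on this read-out lower numbers stand for a stronger effect and higher numbers for a weaker effect at the one concentration tested), and compound 2 `CC(C)c1ccc(NC(=O)N[C@H](C)c2ccccc2)cc1` gives 79%.

Compound 2 thus stands at the lower of the two numbers in this assay, compound 1 being the nearer number, with a gap between them that lies beyond the usual scatter. The step under consideration leads to compound 3 `CC(C)c1ccc(NC(=O)N[C@@H](C)c2ccccc2)cc1`, which differs from compound 2 in this way: the two compounds have the same atoms and bonds and differ only in configuration as drawn: 1 of 1 stereo elements differ; a stereocentre at a saturated chain carbon is drawn R in compound 2 and S in compound 3. For the measured compounds named here, no step of this kind has been measured, so the expectation in this assay is a modest upward step, close to the edge of the scatter. The step expected is a number 9 percentage points higher from compound 2 to compound 3 (within the scatter). Compound 3 is therefore expected to give 88%, in a range from 65% to 100%.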

Compound 3, a percentage reported as activity, at one concentration (the size of the read-out at that concentration, not a potency): 96%
The estimate for compound 3 lay 8 percentage points below the measured number, within the range that was stated.
By their numbers in this assay, from the lowest: compound 2; then compounds 3 and 1 (each within the scatter of the next).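

In this assay the stereocentre at the saturated chain carbon proves to matter, with a number 17 percentage points higher from compound 2 to compound 3 (beyond the scatter), and the pair is separated by configuration alone: the fact that compounds 2 and 3 differ only in the configuration as drawn. With the configuration kept, isopropyl in place of methyl on an aromatic carbon gives a number 3 percentage points lower from compound 1 to compound 3 (within the scatter), so this exchange cannot be told from the scatter. As far as these compounds go, whether the configuration step also holds with methyl on the aromatic carbon stays open, as does how a methoxy group or a longer chain there would read in this assay.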